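The compounds below may be only part of what the source reports. "The series", "measured", "known", "first", "only" and "open" are said of these compounds alone.

Of the compounds shown here, three built on one shared core have been tested in a functional assay on RPMI-8226 cells (Homo sapiens) for cytotoxicity, read by sulforhodamine B assay, with a stated time of 48 h, tested at 0.1 uM; on this read-out higher numbers stand for a weaker effect at the one concentration tested and lower numbers for a stronger effect. Compound 1 `COc1cc(-c2cc(/C=C/C(=O)c3ccc(Cl)c(Cl)c3)[nH]n2)cc(OC)c1OC` gives 95% in this assay. Compound 3 `COc1ccc(-c2cc(/C=C/C(=O)c3ccc(N)cc3)[nH]n2)cc1` gives 100%, and compound 2 `COc1ccc(-c2cc(/C=C/C(=O)c3cc(OC)c(OC)c(OC)c3)[nH]n2)cc1OC` gives 85%. On these numbers compound 1 sits second highest of the three, yet its gap to compound 3 and its gap to compound 2 both lie within the usual scatter of repeated measurements, so the three cannot be told apart on this read-out, and each shows only a weak effect at the single concentration tested.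

Compound 4 `COc1ccc(C(=O)/C=C/c2cc(-c3cc(OC)c(OC)c(OC)c3)n[nH]2)cc1OC` has not yet been measured in this assay. It differs from compound 1 in one place: 3,4-dimethoxyphenyl in place of 3,4-dichlorophenyl on a carbonyl carbon

Within the data shown here, no pair of measured compounds differs in a single group, so there is nothing to measure the size of this kind of change against directly. What the data do show is that compound 2, which also carries a 3,4-dimethoxyphenyl group, gives 85%, within the scatter of compound 1. A step of no size beyond the scatter is therefore expected, in no particular direction. Compound 4 is estimated to give about 92%, within a range from 80% to 100%. That estimate means an expected step of a number 3 percentage points lower from compound 1 to compound 4 (within the scatter), which is none beyond the scatter.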

Compound 4, a percentage reported as activity, at one concentration (the size of the read-out at that concentration, not a potency): 79%
Compound 4: the middle estimate sits 13 percentage points above what was measured; measured number below the stated range.
By their numbers in this assay, from the lowest: compounds 4, 2, 1 and 3 (each within the scatter of the next, the first and the last beyond it).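

In this assay, among these compounds, putting 3,4-dimethoxyphenyl in place of 3,4-dichlorophenyl on the carbonyl carbon gives a number 16 percentage points lower from compound 1 to compound 4 (beyond the scatter), and this is the first pair that differs in one place, so the size of a single change can be read for the first time. It shows that the group on this carbonyl carbon is not a silent part of the molecule: exchanging it alone moves the read-out toward a stronger effect at the one concentration tested, even if only modestly, and this single concentration gives no measure of potency. Why the two groups differ in this way cannot be told from the data, as nothing measured here bears on a cause.

As far as these compounds go, it remains open whether a group such as a nitrile, a carboxylic acid or a trifluoromethyl on the same phenyl ring would move the read-out further, or in the other direction. From the compounds shown here alone, it is also open whether this exchange would give a step of similar size if the group at the other end of the shared core were different.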